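This account rests on a few compounds, and the source may have more. Where it says the series, first, only, none or still open, it means among the compounds named here.

Measured so far in an assay on HEK-293T cells for displacement of a labelled ligand from corticotropin-releasing factor receptor 1 (Homo sapiens), read by scintillation counting, with a stated time of 2 h; a higher number here means a weaker inhibitor, a lower number a stronger inhibitor:
compound 1 `CCCCN(CC)c1cc(C)nc2c1NC(=O)CN2c1ccc(Br)cc1Cl`: 2.7 nM
compound 2 `CCCCN(CC)c1cc(C)nc2c1NC(=O)CN2c1ccc(Br)cc1Br`: 1.3 nM

Compound 2 gives the lowest of the two numbers in this assay; the only other, compound 1, sits a 2.1-fold lower number from compound 1 to compound 2 (0.32 log units; beyond the scatter) away. Compound 3 `CCCCN(CC)c1cc(C)nc2c1NC(=O)CN2c1ccc(Cl)cc1Br` carries chloro in place of bromo on an aromatic carbon, the group meta to a bromo group and para to a large group, so the aryl reads 2,4-dibromophenyl to 2-bromo-4-chlorophenyl. Among the compounds with values here, the one step with bearing, a 2.1-fold lower number from compound 1 to compound 2 (0.32 log units; beyond the scatter), is the same halogen swap at another position and run the other way; a modest rise in the number is therefore expected, a 1.5-fold higher number from compound 2 to compound 3 (0.19 log units; within the scatter). Compound 3 is estimated at 2 nM, range 1 nM to 4.5 nM.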

Compound 3, inhibition constant: 2.5 nM
Beside the measured number, compound 3's estimate is 1.3-fold (0.10 log units) below it; measured number inside the range.
By their numbers in this assay, from the lowest: compounds 2, 3 and 1 (each within the scatter of the next, the first and the last beyond it).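

In this assay, chloro and bromo at the position para to a large group are not separated (a 1.9-fold higher number from compound 2 to compound 3 (0.28 log units; within the scatter)), whereas the swap at the other halogen gave a modest step beyond the scatter (a 2.1-fold lower number from compound 1 to compound 2 (0.32 log units; beyond the scatter)). Exchanging the two halogens on the aryl also leaves the number within the scatter (a 1.1-fold lower number from compound 1 to compound 3 (0.03 log units; within the scatter)). No available evidence bears on this result.

From the compounds shown here alone, whether methoxy, trifluoromethyl or fluoro at this position would stay in the same range remains open. Going by these compounds, the effect of plain hydrogen there is equally open.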